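The source may report more compounds than this note shows. Statements on the series, on what has been measured and on what is new or still open speak of the compounds shown alone.

In a functional assay on DU-145 cells (Homo sapiens) for cytotoxicity, read by MTT assay, with a stated time of 72 h (a lower number here means a stronger inhibitor, a higher number a weaker inhibitor), compound 1 `CC(=O)n1cc(/C=C(/C(=O)O)c2ccccc2)c2cc(OCc3ccccc3)ccc21` gives 26700 nM. Compound 2 `CC(=O)n1cc(/C=C(/C(=O)O)c2ccc(OCc3ccccc3)cc2)c2cc(OCc3ccccc3)ccc21` gives 1410 nM in this assay, and compound 3 `COc1ccccc1/C(=C\c1cn(C(C)=O)c2ccc(OCc3ccccc3)cc12)C(=O)O` gives 1010 nM. Compound 3 thus holds the lowest of the three numbers, though its gap to compound 2 lies within the scatter; only compound 1 stands clearly apart from it. Compound 4 `CC(=O)n1cc(/C=C(/C(=O)O)c2ccc(Cl)cc2)c2cc(OCc3ccccc3)ccc21` differs from compound 3 by 4-chlorophenyl in place of 2-methoxyphenyl on a double-bonded chain carbon bound to a carbonyl carbon and a double-bonded chain carbon. Going by the values given here, two measured steps bear on this: a 19-fold lower number from compound 1 to compound 2 (1.28 log units; beyond the scatter) and a 26-fold lower number from compound 1 to compound 3 (1.42 log units; beyond the scatter), both large, both adding a group to an otherwise bare phenyl. Nothing shows how a chlorine group compares with methoxy or benzyloxy, so compound 4 is expected to land between compound 1 and compound 3. The expected step is a 3.5-fold higher number from compound 3 to compound 4 (0.54 log units; beyond the scatter). Compound 4 is estimated at 3500 nM, between 900 nM and 14000 nM.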

Compound 4, half-maximal inhibitory concentration: 1130 nM
Beside the measured number, compound 4's estimate is 3.1-fold (0.49 log units) above it, within the range that was stated.
By their numbers in this assay, from the lowest: compounds 3, 4 and 2 (each within the scatter of the next); then compound 1.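

Chloro in place of hydrogen on the phenyl gives a 24-fold lower number from compound 1 to compound 4 (1.37 log units; beyond the scatter) in this assay, so a group with no oxygen also carries the large drop. Exchanging the groups changes little: a 1.1-fold higher number from compound 3 to compound 4 (0.05 log units; within the scatter) and a 1.2-fold lower number from compound 2 to compound 4 (0.10 log units; within the scatter) both stay within the scatter, so 4-chlorophenyl, with no hydrogen-bond acceptor, cannot be told apart from 2-methoxyphenyl at this chain carbon. Nothing available explains why these substituted phenyls read alike. Still open, as far as these compounds go, is whether an amine or a carboxylic acid on this phenyl would hold the number. Also open is whether a 2-chlorophenyl or a 4-methoxyphenyl would read the same as the groups shown.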